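Sulfonyl Aryl Swap Followed Across Four Compounds

The source may report more compounds than this note shows. Statements on the series, on what has been measured and on what is new or still open speak of the compounds shown alone.

Compound 3 `CNCc1cn(S(=O)(=O)c2cccc(OC)n2)c(-c2cccnc2F)c1F` has been run in an ADME assay on the whole organism (plasma, Rattus norvegicus, strain Sprague-Dawley) for pharmacokinetics, read by LC-MS, using cassette dosing, at a dose of 0.2 mg/kg by the intravenous route (a higher number here means more compound in the circulation at the dose given, a lower number less compound in the circulation), where compound 3 gives 50 ng.h/mL. Of the three numbers recorded it is the highest, though the gaps to the others lie within the scatter: compound 2 `CNCc1cn(S(=O)(=O)c2ccoc2)c(-c2cccnc2F)c1F` gives 41 ng.h/mL, and compound 1 `CNCc1cn(S(=O)(=O)c2ccco2)c(-c2cccnc2F)c1F` gives 26 ng.h/mL. The steps between them are all modest, with a 1.2-fold higher number from compound 2 to compound 3 (0.09 log units; within the scatter), a 1.9-fold higher number from compound 1 to compound 3 (0.28 log units; within the scatter) and a 1.6-fold higher number from compound 1 to compound 2 (0.20 log units; within the scatter). Since none of these exceeds the usual scatter, the three compounds cannot be ranked against one another on these readings.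

Compound 4 `CNCc1cn(S(=O)(=O)c2cccnc2C)c(-c2cccnc2F)c1F` has not yet been measured. It differs from compound 3 in a single place: 2-methylpyridin-3-yl in place of 6-methoxypyridin-2-yl on a sulfonyl sulfur. Going by the values given here, every measured step so far also exchanged the group on that same sulfonyl sulfur, and each of those exchanges left the number within the scatter. Among the compounds with values here, no other step bears on the change. The expectation for compound 4 in this assay is therefore no step beyond the scatter, with a 1.3-fold lower number from compound 3 to compound 4 (0.10 log units; within the scatter). Compound 4 is estimated at 40 ng.h/mL, within a range from 20 ng.h/mL to 80 ng.h/mL.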

Compound 4, area under the concentration-time curve: 32 ng.h/mL
Compound 4: middle estimate off by 1.3-fold (0.10 log units), on the high side; measured number inside the range.
By their numbers in this assay, from the lowest: compounds 1, 4, 2 and 3 (each within the scatter of the next).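

In this assay the arrival of 2-methylpyridin-3-yl on the sulfonyl sulfur stays within the scatter of all three earlier compounds, the steps reading (a 1.6-fold lower number from compound 3 to compound 4 (0.19 log units; within the scatter)), (a 1.3-fold lower number from compound 2 to compound 4 (0.11 log units; within the scatter)) and (a 1.2-fold higher number from compound 1 to compound 4 (0.09 log units; within the scatter)). The earlier compounds had shown this only for the two furans and 6-methoxypyridin-2-yl, whereas this exchange also removes the oxygen atom of the methoxy group and puts a methyl group on the pyridine ring, and the number still stays within the scatter. Across these four compounds, then, the sulfonyl position tolerates all four aromatic groups without any step that can be told from the scatter, and no ranking among them can be drawn.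

From the compounds shown here alone, the four compounds carry only aromatic rings on this sulfur and share the rest of the core, so it remains open whether a saturated alkyl chain there, or a ring bearing a carboxylic acid or an amine, would move the number beyond the scatter. No supporting measurement is available to explain why these four readings stay so close together.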